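Swapping thiophen-3-yl for 3-cyanophenyl in compound 1

This account rests on a few compounds, and the source may have more. Where it says the series, first, only, none or still open, it means among the compounds named here.

For the measured compounds named here, in an in vivo ADME assay on the whole organism for pharmacokinetics, with Rattus norvegicus as the target (a higher number here means that a larger share of the oral dose reaches the circulation, a lower number that a smaller share of the oral dose reaches the circulation), compound 1 `O=C(Nc1cccnc1-c1ccsc1)N1CCN2C(=O)N([C@H]3C[C@@H]3c3ccccc3)C(=O)[C@@H]2C1` gives 41%, the higher of the two numbers so far, and compound 2 `O=C(Nc1cccc(Cl)c1Cl)N1CCN2C(=O)N([C@H]3C[C@@H]3c3ccccc3)C(=O)[C@@H]2C1` gives 30%. The next structure, compound 3 `N#Cc1cccc(-c2ncccc2NC(=O)N2CCN3C(=O)N([C@H]4C[C@@H]4c4ccccc4)C(=O)[C@@H]3C2)c1`, keeps the rest of compound 1 and carries 3-cyanophenyl in place of thiophen-3-yl on an aromatic carbon. Going by the values given here, only one measured step bears on this change, and only loosely: a number 11 percentage points lower from compound 1 to compound 2 (beyond the scatter). That step exchanges the whole 2-(thiophen-3-yl)pyridin-3-yl group for 2,3-dichlorophenyl on an amide-type nitrogen. Among the compounds with values here, no measured step changes thiophen-3-yl alone, so the direction is poorly fixed. A smaller step than that modest one is expected, slightly downward and within the scatter: a number 6 percentage points lower from compound 1 to compound 3 (within the scatter), as estimated. For compound 3 the estimated value in this assay is 35%, with an expected range from 18% to 52%.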

Compound 3, oral bioavailability: 43%
The estimate for compound 3 lay 8 percentage points below the measured number; the range from low to high includes it.
By their numbers in this assay, from the lowest: compound 2; then compounds 1 and 3 (each within the scatter of the next).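

For the compounds shown here, this is the first step that changes only the group on the aromatic carbon next to the ring nitrogen, whereas the earlier step exchanged the whole aryl group on the amide-type nitrogen. In this assay, the step reads a number 2 percentage points higher from compound 1 to compound 3 (within the scatter), so thiophen-3-yl with 5 heavy atoms and 3-cyanophenyl with 8 heavy atoms cannot be told apart at this place, even though a five-membered aromatic ring gives way to a six-membered one carrying a nitrile. No measurement available here explains this result.

As far as these compounds go, whether the nitrile matters on its own, apart from the phenyl ring carrying it, stays open. Also open, from the compounds shown here alone, is how this assay would read with an amine or a carboxylic acid at this place on the phenyl ring.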